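A larger side group on compound 1

This account rests on a few compounds, and the source may have more. Where it says the series, first, only, none or still open, it means among the compounds named here.

Compound 1 `CC(C)(C)c1ccccc1Oc1ncccc1NC(=O)Nc1ccc(C2(CO)CC2)cc1` gives 5 ug/mL
Compound 2 `CN(C)CC(C)(C)COc1ccc(NC(=O)Nc2cccnc2Oc2ccccc2[Si](C)(C)C)cc1` gives 173 ug/mL
Compound 3 `CC(C)N1CCC(COc2ccc(NC(=O)Nc3cccnc3Oc3ccccc3C(C)(C)C)c(F)c2)CC1` gives 232 ug/mL

These three results come from a physicochemical assay for solubility, in phosphate buffer, at pH 6.5 (a higher number here means a more soluble compound, a lower number a less soluble compound), and compound 1 stands lowest among them, with both other compounds beyond the scatter above it. Compound 2 and compound 3 lie within the scatter of each other.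

Compound 4 `CC(C)CN1CCC(COc2ccc(NC(=O)Nc3cccnc3Oc3ccccc3C(C)(C)C)cc2)CC1` has not been measured yet. Within the data shown here, it carries (1-isobutylpiperidin-4-yl)methoxy in place of 1-(hydroxymethyl)cyclopropyl on an aromatic carbon and no measured pair shows a step of this kind directly. The nearest guide is compound 3 (at 232 ug/mL) whose side group closely resembles the incoming one, though it is not identical and the ring bearing it differs too. Compound 2 (at 173 ug/mL) points the same way. A clear rise is therefore expected in this assay and the expected step is a 30-fold higher number from compound 1 to compound 4 (1.48 log units; beyond the scatter) which would lie beyond the scatter. For compound 4 the estimated value is 150 ug/mL (likely range 40 ug/mL to 500 ug/mL).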

Compound 4, solubility: 27 ug/mL
Compound 4: the middle estimate sits 5.6-fold (0.74 log units) above what was measured; measured number below the stated range.
By their numbers in this assay, from the lowest: compound 1; then compound 4; then compounds 2 and 3 (each within the scatter of the next).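

In this assay, placing (1-isobutylpiperidin-4-yl)methoxy in place of 1-(hydroxymethyl)cyclopropyl, on an aromatic carbon para to a large group, gives a 5.4-fold higher number from compound 1 to compound 4 (0.73 log units; beyond the scatter). Among these compounds, this is the first step in the set with a single change, since the earlier compounds differ in more than one place, and it shows a modest rise beyond the scatter for a much larger group that adds a ring nitrogen and loses the hydrogen-bond donor. Nothing measured here explains the rise.

This one step cannot separate the contribution of the ring nitrogen from that of the added size or the lost hydroxyl. Also open, on these data alone, is how this position would respond to a morpholine ring, or to a methyl group in place of the isobutyl on the ring nitrogen.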